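Two analogues and a dichlorophenyl replacement at the cinnamamide

This account rests on a few compounds, and the source may have more. Where it says the series, first, only, none or still open, it means among the compounds named here.

The series is followed in an assay on isolated protein for displacement of a labelled ligand from melanin-concentrating hormone receptor 1 (Homo sapiens); on this read-out lower numbers stand for stronger inhibition and higher numbers for weaker inhibition. Compound 1 `CCCc1cc(NC)c2cc(NC(=O)/C=C/c3ccc(C(F)(F)F)cc3)ccc2n1` gives 1.5 nM. Compound 2 `CCCc1cc(N)c2cc(NC(=O)/C=C/c3ccc(O)cc3)ccc2n1` gives 1100 nM, the highest of the two numbers recorded, far beyond the scatter away from compound 1. Among the measured compounds shown here, no pair of measured compounds differs in a single place, so no step size is established directly. Compound 3 `CCCc1cc(N)c2cc(NC(=O)/C=C/c3ccc(Cl)c(Cl)c3)ccc2n1` differs from compound 2 by 3,4-dichlorophenyl in place of 4-hydroxyphenyl on a double-bonded chain carbon bound to a double-bonded chain carbon. The step from compound 2 to compound 3 is expected to be large and downward, a 37-fold lower number from compound 2 to compound 3 (1.56 log units; beyond the scatter), beyond the scatter. Compound 3 is therefore estimated at 30 nM, within a range of 5 nM to 200 nM.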

Compound 3, half-maximal inhibitory concentration: 60 nM
The estimate for compound 3 lay 2.0-fold (0.30 log units) below the measured number, within the range that was stated.
By their numbers in this assay, from the lowest: compound 1; then compound 3; then compound 2.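

In this assay, among the compounds shown here, the step is an 18-fold lower number from compound 2 to compound 3 (1.26 log units; beyond the scatter) with 3,4-dichlorophenyl in place of 4-hydroxyphenyl, the first change in a single place. It shows that this position on its own can move the number well beyond the scatter. Nothing given here accounts for the size of the step.

Because both chlorine atoms enter and the hydroxyl group leaves in one change, their separate shares stay unresolved. Going by these compounds, it also remains open how 4-chlorophenyl, 3-chlorophenyl or 4-methoxyphenyl would read at this place.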